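Adding a Fluorine to the Ethyl Arm of Compound 3

The source may report more compounds than this note shows. Statements on the series, on what has been measured and on what is new or still open speak of the compounds shown alone.

Compound 3 `CCc1cccc(NC(=O)Nc2ccc(Oc3cc(NC)ncn3)cc2)c1` gives 200 nM in an assay on isolated protein for inhibition of serine/threonine-protein kinase TNNI3K (Homo sapiens) (on this read-out lower numbers stand for stronger inhibition and higher numbers for weaker inhibition), the second highest of three numbers shown here. Its nearest neighbour is compound 1 `CNc1cc(Oc2ccc(NC(=O)Nc3cccc(CF)c3)cc2)ncn1`, which gives 400 nM; the step of a 2.0-fold lower number from compound 1 to compound 3 (0.30 log units; within the scatter) is within the scatter. The furthest is compound 2 `CNc1cc(Oc2ccc(NC(=O)Nc3cccc(C(F)(F)F)c3)cc2)ncn1`, which gives 40 nM; the step of a 5.0-fold higher number from compound 2 to compound 3 (0.70 log units; beyond the scatter) lies beyond it. Compound 4 `CNc1cc(Oc2ccc(NC(=O)Nc3cccc(C(C)F)c3)cc2)ncn1` differs from compound 3 in one place: fluoro in place of hydrogen on a saturated chain carbon bound to an aromatic carbon and a saturated chain carbon. Among the measured compounds shown here, two steps bear on this. The step of a 10-fold lower number from compound 1 to compound 2 (1.00 log units; beyond the scatter) shows the number falling as fluorine is added at that carbon, while a 2.0-fold lower number from compound 1 to compound 3 (0.30 log units; within the scatter) shows fluoromethyl and ethyl as indistinguishable. A small step toward a lower number is therefore expected for compound 4, a 1.7-fold lower number from compound 3 to compound 4 (0.22 log units; within the scatter). Compound 4 is estimated at 120 nM, within the range 40 nM to 350 nM.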

Compound 4, half-maximal inhibitory concentration: 79 nM
Compound 4: middle estimate off by 1.5-fold (0.18 log units), on the high side; the range from low to high includes it.
By their numbers in this assay, from the lowest: compounds 2 and 4 (each within the scatter of the next); then compounds 3 and 1 (each within the scatter of the next).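

A fluorine on this saturated chain carbon counts for more than the fluoromethyl and ethyl comparison suggested: in this assay, changing ethyl to 1-fluoroethyl gives a 2.5-fold lower number from compound 3 to compound 4 (0.40 log units; beyond the scatter). Adding a methyl to the fluoromethyl carbon also matters, with a 5.1-fold lower number from compound 1 to compound 4 (0.70 log units; beyond the scatter), whereas 1-fluoroethyl and trifluoromethyl cannot be told apart, with a 2.0-fold higher number from compound 2 to compound 4 (0.30 log units; within the scatter). Nothing measured here gives a reason for these steps. Still open, going by these compounds, is how 1,1-difluoroethyl or a hydroxyl or amine on this carbon would compare in this assay.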